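Replacing the indolyl group of compound 2 with dimethylaminophenyl

A few compounds are considered here, and "the series" means these few. Any claim that something is new, unique, unknown or untested is made for them only; others in the source may bear on it.

In a functional assay on MCF7 cells (Homo sapiens) for inhibition, read by CCK-8 assay, with a stated time of 48 h (on this read-out higher numbers stand for weaker inhibition and lower numbers for stronger inhibition), compound 1 (`COc1cc(-c2ccnc3cc(-c4ccc(C)cc4)nn23)cc(OC)c1OC`) gives 47 nM, and compound 2 (`COc1cc(-c2ccnc3cc(-c4ccc5c(ccn5C)c4)nn23)cc(OC)c1OC`) gives 3 nM, the lower of the two numbers. For the measured compounds named here, the only measured step, a 16-fold lower number from compound 1 to compound 2 (1.19 log units; beyond the scatter), is large and beyond the scatter. It exchanges 4-methylphenyl for 1-methyl-1H-indol-5-yl on an aromatic carbon of the shared core.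

Compound 3 (`COc1cc(-c2ccnc3cc(-c4ccc(N(C)C)cc4)nn23)cc(OC)c1OC`) is unmeasured and changes that same place. It carries 4-(dimethylamino)phenyl in place of 1-methyl-1H-indol-5-yl on an aromatic carbon. Like the 4-methylphenyl of compound 1, the entering group is a substituted phenyl, so the measured step of a 16-fold lower number from compound 1 to compound 2 (1.19 log units; beyond the scatter) is the one that bears on this change, read in reverse. Going by the values given here, no measured compound carries the 4-(dimethylamino)phenyl group, so the data do not show how far the number would return towards that of compound 1.

In this assay a moderate rise beyond the scatter is expected, smaller than the measured step, and the estimated step is a 5.0-fold higher number from compound 2 to compound 3 (0.70 log units; beyond the scatter). For compound 3 the estimated value is 15 nM, with an expected range from 4 nM to 60 nM.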

Compound 3, half-maximal inhibitory concentration: 44 nM
For compound 3 the middle estimate is 2.9-fold (0.47 log units) below the measured one; measured number inside the range.
By their numbers in this assay, from the lowest: compound 2; then compounds 3 and 1 (each within the scatter of the next).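

In this assay, the low number of compound 2 does not carry over to 4-(dimethylamino)phenyl on this aromatic carbon (a 15-fold higher number from compound 2 to compound 3 (1.17 log units; beyond the scatter)), so a nitrogen in the entering group is not enough to keep it. Dimethylamino in place of methyl on the phenyl ring leaves no readable difference (a 1.1-fold lower number from compound 1 to compound 3 (0.03 log units; within the scatter)), which sets 1-methyl-1H-indol-5-yl apart from both substituted phenyl groups among the three compounds shown. The data at hand offer no measured explanation for this separation.

The compounds shown do not separate a contribution of the fused ring from that of its methyl group, and 1H-indol-5-yl or 1-methyl-1H-indol-6-yl would be needed to test how much of the low number of compound 2 depends on either feature. From the compounds shown here alone, whether other phenyl substituents, such as methoxy or fluoro, also fall level with methyl and dimethylamino remains open, as does any change elsewhere on the shared core.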